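A Methoxy Group Moved Onto the Core of Compound 1

A few compounds are considered here, and "the series" means these few. Any claim that something is new, unique, unknown or untested is made for them only; others in the source may bear on it.

Of the compounds shown here, three have been measured in a functional assay on HL-60 cells (Homo sapiens) for cytotoxicity, read by CCK-8 assay, with a stated time of 72 h; a lower number here means a stronger inhibitor, a higher number a weaker inhibitor. Compound 1 `CC(C)(C)OC(=O)/C=C1/C(=O)Nc2ccccc21` gives 2450 nM in this assay. Compound 2 `CN1C(=O)/C(=C/C(=O)Oc2ccccc2)c2ccccc21` gives 10200 nM, and compound 3 `COc1ccc(OC(=O)/C=C2/C(=O)N(C)c3ccccc32)cc1` gives 10600 nM. Compound 1 stands apart from the other two, whose numbers lie close together. The difference between the core of compound 1 and the core of compound 2 is not broken down here.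

Compounds 2 and 3 differ in one place: methoxy in place of hydrogen on an aromatic carbon. That change gave a 1.0-fold higher number from compound 2 to compound 3 (0.02 log units; within the scatter).

Compound 4 `COc1cccc2c1NC(=O)/C2=C/C(=O)OC(C)(C)C` has not yet been measured. It arises from compound 1 by the same kind of change, (methoxy in place of hydrogen on an aromatic carbon), but the surroundings are not the same. In compound 3 the methoxy sits para to a large group, whereas in compound 4 it sits on a six-membered aromatic ring of carbon only that is part of a fused or bridged system of two rings, ortho to a fused ring and meta to a fused ring. Going by the values given here, the only measured precedent is a single pair whose step stayed within the scatter, and that is the sole basis for the expectation. For compound 4 the expected step is a 1.1-fold higher number from compound 1 to compound 4 (0.06 log units; within the scatter). The estimated value of compound 4 in this assay is 2800 nM, expected to fall between 1200 nM and 7000 nM.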

Compound 4, half-maximal inhibitory concentration: 9680 nM
The estimate for compound 4 lay 3.5-fold (0.54 log units) below the measured number, outside the stated range (above it).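

In this assay, putting methoxy in place of hydrogen on an aromatic carbon of the core of compound 1 gave a 4.0-fold higher number from compound 1 to compound 4 (0.60 log units; beyond the scatter), so the weaker result came with this one change. Set beside the earlier pair, the same kind of change did not give the same result on the two cores: the same change on two cores in this assay, a 1.0-fold higher number (0.02 log units; within the scatter) from compound 2 to compound 3 and a 4.0-fold higher number (0.60 log units; beyond the scatter) from compound 1 to compound 4, 3.8-fold (0.58 log units) apart, beyond the scatter of two such steps. Going by these compounds alone, this shows that, in this series, the step seen on one core cannot simply be carried over to another, but it does not show what sets the two steps apart, as the methoxy sits on a different ring in each pair, the surrounding structures differ, and each core offers only a single pair.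

The compounds shown leave open whether this step belongs to methoxy in particular or would also appear with another small group at the same place on the core of compound 1, such as a methyl group, a chlorine atom or a hydroxyl group. They also leave open whether methoxy on one of the other aromatic carbons of that six-membered ring would give a step of similar size.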